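Quinazolinone series: methyl to trifluoromethoxy on the aryl ring

The compounds below may be only part of what the source reports. "The series", "measured", "known", "first", "only" and "open" are said of these compounds alone.

Within the data shown here, the three measured members share one core and differ in the groups on the pendant aryl ring and on the fused ring. In an assay on isolated protein for inhibition of DNA topoisomerase 1 (Homo sapiens), with a stated time of 30 min, tested at 20 uM (a higher number here means a stronger effect of the compound at the concentration tested, a lower number a weaker effect), compound 2 `Cc1ccc2c(=O)[nH]c(-c3ccccc3C)nc2c1` gives 39.2%, the highest of the three numbers. Compound 3 `Cc1cccc(-c2nc3ccc(C)cc3c(=O)[nH]2)c1` gives 12.7% in this assay, a number lower by more than the scatter. Compound 1 `COc1cccc(-c2nc3ccc(N4CCCCC4)cc3c(=O)[nH]2)c1OC` gives 0% in this assay, the lowest number of the set and again beyond the scatter from compound 2. No two of these compounds differ in one place only, so no single step can be read from them.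

Compound 4 `Cc1ccc2c(=O)[nH]c(-c3ccccc3OC(F)(F)F)nc2c1` is not yet measured. Relative to compound 2 the change is trifluoromethoxy in place of methyl on an aromatic carbon, on an aromatic carbon of a six-membered aromatic ring of carbon only, ortho to a large group. Nothing in the measured set isolates the effect of a change at this place. With compound 2 standing at 39.2% and the other two numbers below it, the expected step for compound 4 is a number 11.2 percentage points lower from compound 2 to compound 4 (beyond the scatter), most likely a modest drop, though a step within the scatter cannot be excluded. Compound 4 is therefore estimated at 28% in this assay, with a range from 5% to 55%.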

Compound 4, a percentage reported as inhibition, at one concentration (the size of the read-out at that concentration, not a potency): 100%
Compound 4: middle estimate off by 72 percentage points, on the low side; the measured number lies above the stated range.
By their numbers in this assay, from the lowest: compound 1; then compound 3; then compound 2; then compound 4.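

Among these compounds, the first step that can be read at a single place lies on an aromatic carbon of the six-membered aromatic ring of carbon only, ortho to a large group: in this assay, trifluoromethoxy in place of methyl gives a number 60.8 percentage points higher from compound 2 to compound 4 (beyond the scatter). The earlier compounds shown here could not show this, as no two of them differed in one place only; it is now clear that the read-out at this place depends strongly on the group it carries, with the shared core and the methyl on the fused ring unchanged across the step. No measured information on these compounds bears on what lies behind the step.

Compound 4 gives 100%, a read-out at one concentration, so the stronger effect of compound 4 than of compound 2 is shown at that concentration only, and how the two compare at other concentrations remains open. Also open, on these data alone, is whether the step follows the oxygen or the fluorines of the entering group, which trifluoromethyl at the same place would help to separate, and whether an amine or a carboxylic acid is accepted there.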